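The compounds below may be only part of what the source reports. "The series", "measured", "known", "first", "only" and "open" are said of these compounds alone.

Measured compounds:

- compound 1, `O=C(Nc1cccc(Cl)c1)c1cc(C(F)(F)F)ccc1OCc1ccc(F)cc1`, 12.6 nM in an assay on Sf9 cells for inhibition of Leucine-rich repeat serine/threonine-protein kinase 2 (Homo sapiens), read by TR-FRET, with stated times of 30 min and 2 h; on this read-out lower numbers stand for stronger inhibition and higher numbers for weaker inhibition
- compound 2, `N#Cc1cccc(NC(=O)c2cc(C(F)(F)F)ccc2OCc2ccc(F)cc2)c1`, 7.94 nM in this assay
- compound 3, `O=C(Nc1ccnnc1)c1cc(N2CCC(F)CC2)ccc1OCc1ccccc1`, 39.8 nM in this assay

Among these three numbers compound 1 stands second highest. Its nearest neighbour is compound 2, which differs from it only in a cyano in place of chloro on an aromatic carbon and gives a 1.6-fold lower number from compound 1 to compound 2 (0.20 log units; within the scatter), a step within the scatter. Compound 3, which differs from compound 1 in several places at once, gives a number beyond the scatter from it.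

The compound not yet measured is compound 4, `O=C(Nc1cccc(Cl)c1)c1cc(C(F)(F)F)ccc1OCc1ccccc1`. It is compound 1 with one change: hydrogen in place of fluoro on an aromatic carbon.

Going by the values given here, none of the measured steps bears on this change. Among the compounds with values here, the only single-point step known, from compound 1 to compound 2, concerns a different position and a different pair of groups, and compound 3 carries the benzyloxy group but cannot be compared in isolation. With nothing showing that a fluoro at this position matters, the step expected in this assay is a 1.2-fold higher number from compound 1 to compound 4 (0.08 log units; within the scatter), that is, nothing beyond the scatter. Compound 4 is therefore estimated at 15 nM, within the range 6 nM to 40 nM.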

Compound 4, half-maximal inhibitory concentration: 25.1 nM
Estimate against measurement, compound 4: 1.7-fold (0.22 log units) below; measured number inside the range.
By their numbers in this assay, from the lowest: compounds 2, 1, 4 and 3 (each within the scatter of the next, the first and the last beyond it).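

In this assay, going by these compounds alone, the change from 4-fluorobenzyl to benzyl on the core of compound 1 gives a 2.0-fold higher number from compound 1 to compound 4 (0.30 log units; within the scatter), and this is the first direct reading of what this fluoro contributes. With the chloro and trifluoromethyl groups held constant, hydrogen can stand in place of fluoro at this aromatic carbon, para to a large group, with no step beyond the scatter, so the fluoro is not shown to be needed for the number to stay in the same range. This single pair cannot show whether a real difference smaller than the scatter lies behind the step, and no measurement available offers an explanation for it.

The compounds shown leave open how this place responds to anything other than fluoro or hydrogen, such as a chloro, a methoxy, an amine or a carboxylic acid on the same carbon of the ring. They also leave open whether the same change reads alike when the chloro of compound 1 is replaced by the nitrile of compound 2, since that benzyl partner does not appear among them.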